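A few compounds are considered here, and "the series" means these few. Any claim that something is new, unique, unknown or untested is made for them only; others in the source may bear on it.

Compound 1 `O[C@@H]1Cc2cc(Cl)ccc2N[C@H](c2ccc(Cl)cc2)C1` gives 76600 nM in an ADME assay on Vero cells (Chlorocebus sabaeus) for cytotoxicity, read by MTT assay, with a stated time of 72 h; on this read-out lower numbers stand for higher toxicity in this test and higher numbers for lower toxicity in this test. Compound 2 `O[C@@H]1Cc2cc(F)ccc2N[C@H](c2ccc(Cl)cc2)C1` gives 194000 nM in this assay, and the step of a 2.5-fold higher number from compound 1 to compound 2 (0.40 log units; beyond the scatter) accompanies the change (fluoro in place of chloro on an aromatic carbon). Compound 3 `O[C@@H]1Cc2ccccc2N[C@H](c2c(Cl)cccc2Cl)C1` holds the same atoms as compound 1 joined differently; the difference between the two cores is not broken down here. In this assay compound 3 reaches only a limit, > 300000 nM. Within the data shown here, compound 4 `O[C@@H]1Cc2ccccc2N[C@H](c2c(F)cccc2Cl)C1` is not yet measured and differs from compound 3 by fluoro in place of chloro on an aromatic carbon, the same kind of change as the one between compound 1 and compound 2, though here the place is ortho to a large group and meta to a chloro group rather than meta to a fused ring and para to a fused ring. For compound 4 a step of roughly a step that the limit leaves unreadable from compound 3 to compound 4 is expected, resting on a 2.5-fold higher number from compound 1 to compound 2 (0.40 log units; beyond the scatter) and on (the limit of > 300000 nM in this assay, at which 1 of the 3 values shown sits). The estimate for compound 4 is 450000 nM, expected between 200000 nM and 1000000 nM.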

Compound 4, half-maximal cytotoxic concentration: > 300000 nM
Compound 4: a limit, no number; the forecaster's own chance of this, stated with the estimate: 75%; the middle value lies beyond the limit too.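

Compound 3 and compound 4 both give only a limit in this assay, so no step can be read between them: the limit of > 300000 nM in this assay, at which 2 of the 4 values shown sit. The compounds shown leave open what fluoro in place of chloro changes on the core of compound 3.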